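This account rests on a few compounds, and the source may have more. Where it says the series, first, only, none or still open, it means among the compounds named here.

Measured so far:
compound 1, `Cc1ccc(NC(=O)CC(=O)O)c2ccn(Cc3ccc(O)c(C(C)C)c3)c12`, 1300 nM;
compound 2, `Cc1cc2c(NC(=O)CC(=O)O)cccc2n1Cc1ccc(O)c(C(C)C)c1`, 220 nM.

In an assay on HepG2 cells for agonist activity at thyroid hormone receptor beta (Homo sapiens), read by reporter gene assay, with a stated time of 10 h (a higher number here means that more compound is needed for the effect, a lower number that less compound is needed), compound 2 gives the lower of the two numbers, with compound 1 standing beyond the scatter from it. The unmeasured compound 3, `Cc1cc2c(NC(=O)C(=O)O)cccc2n1Cc1ccc(O)c(C(C)C)c1`, departs from compound 2 by carboxy in place of carboxymethyl on a carbonyl carbon, a carboxy in place of a carboxymethyl on a carbonyl carbon whose other neighbour is an amide-type nitrogen. Within the data shown here, no measured pair shows this change, so no step size is known; the change is expected to stay near compound 2 or move a little toward a lower number. The step expected in this assay is a 1.5-fold lower number from compound 2 to compound 3 (0.17 log units; within the scatter). Compound 3 is estimated at 150 nM, within 40 nM to 600 nM.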

Compound 3, half-maximal effective concentration: 110 nM
Compound 3: the middle estimate sits 1.4-fold (0.13 log units) above what was measured, and the stated range covers the measured number.
By their numbers in this assay, from the lowest: compounds 3 and 2 (each within the scatter of the next); then compound 1.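

Among these compounds, on the carbonyl carbon whose other neighbour is an amide-type nitrogen, carboxy in place of carboxymethyl gives in this assay a 2.0-fold lower number from compound 2 to compound 3 (0.30 log units; within the scatter) and so is the first single change read. The carboxymethyl can therefore give way to carboxy at this place without a difference beyond the scatter, and compound 2 and compound 3 cannot be ranked. No evidence on the reason for this is at hand. Open, going by these compounds, is whether a longer chain such as carboxyethyl would read the same, and how a tetrazole or a primary amide would read at this place.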